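The source may hold more compounds than are shown below. What is called first, only, known or untested is meant among the compounds shown, and "the series" means these compounds.

Measured in a functional assay on HT-29 cells (Homo sapiens) for cytotoxicity, read by MTT assay, with a stated time of 24 h, tested at 0.64 ug/mL; on this read-out lower numbers stand for a weaker effect and higher numbers for a stronger effect at the one concentration tested:
compound 1, `Cn1c(-c2ccc(NC(=O)CSc3nc4cc(Cl)ccc4o3)cc2)nc(-c2ccccc2)c1-c1ccccc1`: 11.9%
compound 2, `Cn1nnnc1SCC(=O)Nc1ccc(-c2nc(-c3ccccc3)c(-c3ccccc3)n2C)cc1`: 38%
compound 3, `CN1CCN(CC(=O)Nc2ccc(-c3nc(-c4ccccc4)c(-c4ccccc4)n3C)cc2)CC1`: 18.8%

Among these three, compound 3 stands below only one of them by a clear margin, a number 19.2 percentage points lower from compound 2 to compound 3 (beyond the scatter), while the other gap is inside the scatter, a number 6.9 percentage points higher from compound 1 to compound 3 (within the scatter). Compound 4, `Cn1c(-c2ccc(NC(=O)CN3CCN(Cc4ccc(Cl)cc4)CC3)cc2)nc(-c2ccccc2)c1-c1ccccc1`, differs from compound 3 in one place: 4-chlorophenyl in place of hydrogen on a saturated chain carbon bound to an amine nitrogen in a ring. Within the data shown here, no measured step touches this position; the two steps that reach the piperazine, a number 6.9 percentage points higher from compound 1 to compound 3 (within the scatter) and a number 19.2 percentage points lower from compound 2 to compound 3 (beyond the scatter), concern what replaced the sulfanyl group, not a substituent on a saturated chain carbon bound to an amine nitrogen in a ring. Nothing therefore points to a change beyond the scatter, and a step of a number 2.2 percentage points higher from compound 3 to compound 4 (within the scatter) is expected. Compound 4 is estimated at 21%, within 8% to 38%.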

Compound 4, a percentage reported as activity, at one concentration (the size of the read-out at that concentration, not a potency): 11.3%
Beside the measured number, compound 4's estimate is 9.7 percentage points above it; low and high end bracket the measured number.
By their numbers in this assay, from the lowest: compounds 4, 1 and 3 (each within the scatter of the next); then compound 2.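

In this assay, the step from methyl to 4-chlorobenzyl on the piperazine nitrogen's saturated chain carbon (a number 7.5 percentage points lower from compound 3 to compound 4 (within the scatter)) shows that this position accepts a 4-chlorophenyl group without a change in the read-out beyond the scatter. Among these compounds, the earlier steps changed only the group on the carbon bound to the carbonyl carbon, so this is the first reading at this position. No measured evidence bears on this result.

Still open, as far as these compounds go, is whether an amine, a carboxylic acid or a longer chain at this position would move the number beyond the scatter.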